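A few compounds are considered here, and "the series" means these few. Any claim that something is new, unique, unknown or untested is made for them only; others in the source may bear on it.

All four compounds rest on the same shared core, and only their two amide arms change. Compound 1 `CN(C)c1ccc(C(=O)Nc2cccc(NC(=O)COc3ccc4c(c3)CCC(=O)N4)c2)cc1` is recorded in an assay on isolated protein for inhibition of Rho-associated protein kinase 1 (Homo sapiens), read by scintillation counting, radiometric assay and 33P incorporation, with a stated time of 40 min, in the presence of a further agent that is not named here (on this read-out lower numbers stand for stronger inhibition and higher numbers for weaker inhibition), only as a limit, at > 10000 nM. Compound 2 `COc1cccc(OCC(=O)Nc2cccc(NC(=O)c3ccc(N(C)C)cc3)c2)c1` likewise reaches only the limit > 10000 nM. The step that the two limits leave unreadable from compound 1 to compound 2 cannot be sized because both its ends sit at the limit (the limit of > 10000 nM in this assay, at which 2 of the 3 values shown sit). Compound 3 `CCCC(=O)Nc1cccc(NC(=O)COc2ccc3c(=O)ccoc3c2)c1`, with a propyl amide, gives 1430 nM in this assay, the only full number shown. Compound 4 `N#Cc1ccc(C(=O)Nc2cccc(NC(=O)COc3ccc4c(=O)ccoc4c3)c2)cc1` differs from compound 3 by 4-cyanophenyl in place of propyl on a carbonyl carbon. No measured step bears on this change, so its size cannot be inferred from the shown data. The estimate for compound 4 is 1000 nM, with a range from 200 nM to 8000 nM. The step of a 1.4-fold lower number from compound 3 to compound 4 (0.16 log units; within the scatter) is therefore expected to stay near the scatter.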

Compound 4, half-maximal inhibitory concentration: 123 nM
The estimate for compound 4 lay 8.1-fold (0.91 log units) above the measured number; measured number below the stated range.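

In this assay the exchange of propyl for 4-cyanophenyl on a carbonyl carbon brings a 12-fold lower number from compound 3 to compound 4 (1.07 log units; beyond the scatter), the only readable step shown, so this position responds clearly to the group it carries. Compound 1 and compound 2 could not show such a response: their values are limits. Nothing given here accounts for the size of this step. The compounds shown leave open whether the gain needs the aromatic ring, the nitrile or both. A plain phenyl, a 4-carboxyphenyl or a longer chain such as hexyl would separate these.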